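A urea side chain gives way to a morpholine amide

The source may report more compounds than this note shows. Statements on the series, on what has been measured and on what is new or still open speak of the compounds shown alone.

Compound 1 `COc1ccc(-c2nc(N=C(N)N)sc2-c2ccc(OC)cc2)cc1` gives 31000 nM
Compound 2 `CNC(=O)NCc1nc(-c2ccc(OC)cc2)c(-c2ccc(OC)cc2)s1` gives 22 nM
Compound 3 `COc1ccc(-c2nc(CNC(=O)NC(C)C)sc2-c2ccc(OC)cc2)cc1` gives 42 nM
Compound 4 `COc1ccc(-c2nc(C(=O)N3CCOCC3)sc2-c2ccc(OC)cc2)cc1` is not yet measured

In a functional assay with Oryctolagus cuniculus as the target (on this read-out higher numbers stand for weaker inhibition and lower numbers for stronger inhibition), compound 3 (42 nM) lies within the scatter of compound 2 and far below compound 1. The next change is (morpholin-4-yl)carbonyl in place of ((isopropylcarbamoyl)amino)methyl on an aromatic carbon and puts (morpholin-4-yl)carbonyl in place of ((isopropylcarbamoyl)amino)methyl on an aromatic carbon. Among the measured compounds shown here, three measured steps bear on it. The steps of a 1400-fold lower number from compound 1 to compound 2 (3.15 log units; beyond the scatter) and a 740-fold lower number from compound 1 to compound 3 (2.87 log units; beyond the scatter) are large, so a change at this place can matter greatly, whereas a 1.9-fold higher number from compound 2 to compound 3 (0.28 log units; within the scatter) is small. For the measured compounds named here, no measured compound carries the entering group, so the direction remains uncertain. In this assay a moderate move towards a higher number is expected, estimated as a 3.6-fold higher number from compound 3 to compound 4 (0.55 log units; beyond the scatter) overall. For compound 4 the estimated value is 150 nM (expected range 15 nM to 3000 nM).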

Compound 4, half-maximal inhibitory concentration: < 10 nM
Compound 4: no number, only a limit (the forecaster's own chance of this, stated with the estimate: 10%); at least 15-fold (1.17 log units) between middle value and limit.
By their numbers in this assay, from the lowest: compounds 2 and 3 (each within the scatter of the next); then compound 1. At a limit, below all of these: compound 4.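

In this assay compound 4 gives < 10 nM, which is a limit of the assay and not a number. With an at least 4.2-fold lower number from compound 3 to compound 4 (0.62 log units; beyond the scatter) and an at least 2.2-fold lower number from compound 2 to compound 4 (0.34 log units; beyond the scatter), this position proves not to need a urea chain or its hydrogen-bond donors, since (morpholin-4-yl)carbonyl has none. an at least 3100-fold lower number from compound 1 to compound 4 (3.49 log units; beyond the scatter) extends the large gain already seen with the urea chains, although each step is only a bound because the read-out ends at a limit: the limit of < 10 nM in this assay, at which 1 of the 4 values shown sits.

The compounds shown leave open how far the true value of compound 4 lies under that limit. They also leave open whether a piperidine amide or a dimethylamide would serve as well at this place.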